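The compounds below may be only part of what the source reports. "The series", "measured", "known", "first", "only" and "open" are said of these compounds alone.

Compound 1 `O=c1[nH]c(=O)n(COCCO)cc1[N+](=O)[O-]` and compound 2 `Nc1nc2c(nc(O)n2COCCO)c(=O)[nH]1` share a (2-hydroxyethoxy)methyl chain on different cores. In a functional assay (Oryctolagus cuniculus) for inhibition (a higher number here means a weaker inhibitor, a lower number a stronger inhibitor), compound 1 reaches only the limit of the test, > 400 ug/mL, so it gives no number. In this assay, going by the values given here, compound 2 gives 48 ug/mL, the only numerical value shown. The other value shown, that of compound 1, is a limit (the limit of > 400 ug/mL in this assay, at which 1 of the 2 values shown sits). Compound 3 `CN(C)c1nc2c(=O)[nH]c(N)nc2n1COCCO` differs from compound 2 by dimethylamino in place of hydroxy on an aromatic carbon. Among the compounds with values here, no measured pair tells how such a change shifts the readout, so the step is expected to be small or within the scatter: a 1.7-fold higher number from compound 2 to compound 3 (0.22 log units; within the scatter) is the estimate. Compound 3 is expected to give about 80 ug/mL, somewhere between 20 ug/mL and 400 ug/mL.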

Compound 3, concentration for 50% inhibition: > 400 ug/mL
Compound 3: only a limit was reported; the forecaster's own chance of this, stated with the estimate: 25%; middle value at least 5.0-fold (0.69 log units) from the limit.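

Replacing hydroxy with dimethylamino on this aromatic carbon, between two ring nitrogen atoms, is not a silent change in this assay: the step is an at least 8.3-fold higher number from compound 2 to compound 3 (0.92 log units; beyond the scatter). For compound 3 the reading is a limit, not a number, so the step has only a lower bound. This place on the core therefore responds to substitution, yet only compound 2 gives a number: the limit of > 400 ug/mL in this assay, at which 2 of the 3 values shown sit.

From the compounds shown here alone, whether an amine, a methoxy group or a methyl group on this carbon would stay close to compound 2 remains open. Going by these compounds, how far compound 3 lies past its limit also remains open.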